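Oxan-4-yl extension at the saturated chain carbon

This account rests on a few compounds, and the source may have more. Where it says the series, first, only, none or still open, it means among the compounds named here.

Compound 2 `CN(Cc1ccc(B(O)O)cn1)c1ccc(C(=O)Nc2ccc(F)cc2)cn1` gives 1700 nM in a functional assay on RBL cells for antagonist activity at C-X-C chemokine receptor type 1 (Homo sapiens), read by fluorescence and calcium flux, with a stated time of 30 min (on this read-out higher numbers stand for weaker inhibition and lower numbers for stronger inhibition), the lowest of the two numbers in hand. Among the compounds with values here, compound 1 `CN(Cc1cccc(B(O)O)c1)c1ccc(C(=O)Nc2ccc(F)cc2)cn1` gives 4100 nM in this assay, and the only measured step is a 2.4-fold lower number from compound 1 to compound 2 (0.38 log units; beyond the scatter). Compound 3 `O=C(Nc1ccc(F)cc1)c1ccc(N(Cc2ccc(B(O)O)cn2)CC2CCOCC2)nc1` is the unmeasured member; it differs from compound 2 by oxan-4-yl in place of hydrogen on a saturated chain carbon bound to a nitrogen on an aromatic ring. Within the data shown here, no measured step bears on this kind of change: the one step in hand exchanges one six-membered aromatic ring for another at the same place and says nothing about attaching a non-aromatic ring to the saturated chain carbon. The expectation in this assay is therefore a step of unknown direction that may well stay within the scatter, with a wide margin for either outcome. Compound 3 is estimated at 1700 nM (range 500 nM to 6000 nM), which is expected to mean no change at the digits printed from compound 2 to compound 3 (within the scatter).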

Compound 3, half-maximal inhibitory concentration: > 5000 nM
Compound 3 was reported as a limit (the forecaster's own chance of this, stated with the estimate: 5%); at least 2.9-fold (0.46 log units) between middle value and limit.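

In this assay, the saturated chain carbon bound to a nitrogen on an aromatic ring does not take oxan-4-yl in place of hydrogen without a loss of inhibition: the change reads as an at least 2.9-fold higher number from compound 2 to compound 3 (0.46 log units; beyond the scatter). Within the data shown here, this is the first reading on this place, as the earlier step covered only the exchange of one six-membered aromatic ring for another. The value of compound 3 is a limit and not a number, so only the minimum size of the step can be read: the limit of > 5000 nM in this assay, at which 1 of the 3 values shown sits.

On these data alone, whether the loss belongs to oxan-4-yl itself or to any group at this place stays open. Ethyl, cyclohexyl or an amine such as piperidin-4-yl at the same carbon would separate these readings, and the compounds shown contain none of these groups.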